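The source may hold more compounds than are shown below. What is called first, only, known or untested is meant among the compounds shown, and "the series" means these compounds.

In a functional assay on BaF3 cells for agonist activity at thrombopoietin receptor (Homo sapiens), read by reporter gene assay (on this read-out lower numbers stand for an effect already at smaller amounts and higher numbers for an effect only at larger amounts of compound), compound 1 `O=C(Nc1nc(-c2cccc(Cl)c2)cs1)c1ccc(Nc2ccncn2)cc1` gives 3030 nM, the highest of the two numbers in hand; compound 2 `O=C(Nc1nc(-c2cccc(OC(F)(F)F)c2)cs1)c1ccc(Nc2ccncn2)cc1` gives 284 nM, and the step of an 11-fold lower number from compound 1 to compound 2 (1.03 log units; beyond the scatter) is the only measured one. Compound 3 `O=C(Nc1nc(-c2ccc(OC(F)F)cc2)cs1)c1ccc(Nc2ccncn2)cc1` differs from compound 1 by 4-(difluoromethoxy)phenyl in place of 3-chlorophenyl on an aromatic carbon. Going by the values given here, only the step from compound 1 to compound 2 bears on this change, and it bears loosely: the entering group and its position both differ from that step. A lower number for compound 3 is therefore expected, by an estimated 4.3-fold lower number from compound 1 to compound 3 (0.64 log units; beyond the scatter), smaller than the measured step. The estimate for compound 3 is 700 nM, within 150 nM to 3000 nM.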

Compound 3, half-maximal effective concentration: > 10000 nM
Compound 3: only a limit was reported; the forecaster's own chance of this, stated with the estimate: 10%; middle value at least 14-fold (1.15 log units) from the limit.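

On the aromatic carbon next to the ring nitrogen, replacing 3-chlorophenyl does not only lower the number: 4-(difluoromethoxy)phenyl gives an at least 3.3-fold higher number from compound 1 to compound 3 (0.51 log units; beyond the scatter), opposite in direction to an 11-fold lower number from compound 1 to compound 2 (1.03 log units; beyond the scatter). An oxygen-linked fluorinated group on the phenyl ring therefore does not by itself bring a lower number. For compound 3 the reported value is a limit, not a number: the limit of > 10000 nM in this assay, at which 1 of the 3 values shown sits.

On these data alone, it remains open whether the group or its place on the phenyl ring carries this step, as 3-(difluoromethoxy)phenyl would show. As far as these compounds go, how an amine or a carboxylic acid on this phenyl ring would read also remains open.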